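Working notes: from compound 2 to compound 3

The compounds below may be only part of what the source reports. "The series", "measured", "known", "first", "only" and "open" are said of these compounds alone.

Measured in a functional assay on HCC827 cells (Homo sapiens) for inhibition, read by MTT assay, with a stated time of 48 h, tested at 10 uM; a higher number here means more inhibition at the concentration tested (going by the name of the read-out), a lower number less inhibition:
compound 1, `COc1cc(NC(=O)Nc2cc(Nc3cccc(C(C)(C)C)c3)ncn2)cc(OC)c1`: 48.7%
compound 2, `COc1cc(NC(=O)Nc2cc(Nc3cc(F)ccc3OC)ncn2)cc(OC)c1`: 59%

Compound 2 holds the higher of the two numbers. Within the data shown here, the one measured step, a number 10.3 percentage points higher from compound 1 to compound 2 (beyond the scatter), came with 5-fluoro-2-methoxyphenyl in place of 3-(tert-butyl)phenyl on a nitrogen on an aromatic ring, a change of the whole ring rather than of one group on it.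

Compound 3, `COc1cc(NC(=O)Nc2cc(Nc3cc(C(F)(F)F)ccc3OC)ncn2)cc(OC)c1`, differs from compound 2 by trifluoromethyl in place of fluoro on an aromatic carbon. Among the measured compounds shown here, no measured step exchanges one group for another on an aromatic carbon of this ring, so the single step known here does not bear directly on the change, and there is no basis for expecting a step beyond the scatter in this assay in either direction.

For compound 3 the estimate in this assay is 58%, with a range from 40% to 75%. The expected step is a number 1 percentage points lower from compound 2 to compound 3 (within the scatter).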

Compound 3, a percentage reported as inhibition, at one concentration (the size of the read-out at that concentration, not a potency): 59.7%
Estimate against measurement, compound 3: 1.7 percentage points below; low and high end bracket the measured number.
By their numbers in this assay, from the lowest: compound 1; then compounds 2 and 3 (each within the scatter of the next).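

In this assay, the exchange of fluoro for trifluoromethyl on this aromatic carbon, para to a methoxy group, gives a number 0.7 percentage points higher from compound 2 to compound 3 (within the scatter). Among these compounds, this is the first measured exchange of one group for another at this position, whereas the earlier step replaced the whole ring. Here, going from 1 heavy atom to 4 heavy atoms leaves the reading within the scatter, so these two groups cannot be told apart in this assay at the concentration tested. No measurement at hand bears on why the two groups read alike.

The compounds shown leave open how an amine or a carboxylic acid on this same aromatic carbon would read, with fluoro and trifluoromethyl the only groups shown there. Also open, on these data alone, is what the methoxy group contributes, since it stays in place in both compound 2 and compound 3.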